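This account rests on a few compounds, and the source may have more. Where it says the series, first, only, none or still open, it means among the compounds named here.

Compound 1, `C[C@@H](O)[C@H]1C(=O)N2C(C(=O)OCOC(=O)C(C)(C)C)=C(S[C@@H]3CN[C@H](C(=O)Nc4cccc(C(=O)O)c4)C3)[C@H](C)[C@H]12`, gives > 95% in an ADME assay for metabolic stability, read by LC-MS, with a stated time of 3 h, at pH 6.5, tested at 50 uM; a higher number here means that more of the compound is left, a lower number that less of the compound is left; this value is a limit of the assay, not a number.
Compound 2, `C[C@@H](O)[C@H]1C(=O)N2C(C(=O)OCOC(=O)OC3CCCCC3)=C(S[C@@H]3CN[C@H](C(=O)Nc4cccc(C(=O)O)c4)C3)[C@H](C)[C@H]12`, gives > 95% in this assay; this too is a limit.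
Compound 3, `CCOC(=O)OCOC(=O)C1=C(S[C@@H]2CN[C@H](C(=O)Nc3cccc(C(=O)O)c3)C2)[C@H](C)[C@@H]2[C@@H]([C@@H](C)O)C(=O)N12`, gives > 95% in this assay; again a limit.

Compound 3 therefore stands at the limit, and so do the other two values shown: the limit of > 95% in this assay, at which 3 of the 3 values shown sit. The steps between the measured compounds, a step that the two limits leave unreadable from compound 1 to compound 2, a step that the two limits leave unreadable from compound 1 to compound 3 and a step that the two limits leave unreadable from compound 2 to compound 3, cannot be read in size, because both ends of each sit at the limit. Compound 4, `COC(=O)OCOC(=O)C1=C(S[C@@H]2CN[C@H](C(=O)Nc3cccc(C(=O)O)c3)C2)[C@H](C)[C@@H]2[C@@H]([C@@H](C)O)C(=O)N12`, differs from compound 3 by hydrogen in place of methyl on a saturated chain carbon bound to an oxygen next to a carbonyl group. The three measured steps are the only ones that bear on this change, and all concern the group on an oxygen next to a carbonyl group; none gives a readable size or direction. What they do show is that three different groups at that place all left the compound at the limit. The step expected in this assay is accordingly a step that the limit leaves unreadable from compound 3 to compound 4, that is, none beyond the scatter, with a high chance that only a limit is reported. Compound 4 is estimated at 96%, with a range from 85% to 100%.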

Compound 4, percent of the compound remaining: > 95%
Compound 4 ended at the assay's limit; the forecaster's own chance of this, stated with the estimate: 80%; the middle value does not contradict the limit.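

Compound 4 sits at the limit together with compound 1, compound 2 and compound 3, so no step among these four compounds can be read in size or direction in this assay: the limit of > 95% in this assay, at which 4 of the 4 values shown sit.

The compounds shown leave open how large any difference among them is in this assay, and which change, if any, would bring a compound off the limit.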